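The source may hold more compounds than are shown below. What is called first, only, known or untested is meant among the compounds shown, and "the series" means these compounds.

- compound 1 `CC(=O)SCCC(CCCCC(=O)O)SC(C)=O` gives 12.4%
- compound 2 `O=C(CCCCC(S)CCS)Nc1ccc(OC(F)(F)F)cc1` gives 6%
- compound 3 `O=C(CCCCC(CCSC(=O)c1ccccc1)SC(=O)c1ccccc1)Nc1ccccc1` gives "not active" (no number reported)

These readings come from a functional assay on KB cells (Homo sapiens) for inhibition, read by MTT assay, with a stated time of 24 h, tested at 1 ug/mL (on this read-out higher numbers stand for more inhibition of growth at the one concentration tested and lower numbers for less inhibition of growth), and they are few. Compound 1 and compound 2 lie within the usual scatter of each other. Compound 3, the starting point here, has no figure at all: compound 3 was reported only as "not active" (no number reported) without a number, so no gap to the other two can be stated.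

The next compound, compound 4 `O=C(CCCCC(CCSC(=O)c1ccccc1)SC(=O)c1ccccc1)Nc1ccc(Cl)cc1`, departs from compound 3 in one place. The change is chloro in place of hydrogen on an aromatic carbon and amounts to chloro in place of hydrogen on an aromatic carbon, para to a large group, with phenyl going to 4-chlorophenyl.

For the measured compounds named here, no measured pair in this small set shows what such a swap does in this assay, so the expectation is modest: a small rise in growth inhibition if any, and none beyond the scatter. Going by the values given here, the only numbers to lean on are those of compound 2 (6%) and compound 1 (12.4%). A report without a number, as for compound 3, would be no surprise. In this assay the estimated value for compound 4 is 7% with an expected range of 0% to 20% at the one concentration tested.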

Compound 4, percent growth inhibition at one concentration: 11.7%
Estimate against measurement, compound 4: 4.7 percentage points below; the measured number falls inside the stated range.
By their numbers in this assay, from the lowest: compounds 2, 4 and 1 (each within the scatter of the next).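

For the compounds shown here, compound 3 has no number in this assay and so no step to compound 4 at 11.7% can be read. Nothing measured here bears on a cause for this reading. The compounds shown leave open what chloro in place of hydrogen, phenyl to 4-chlorophenyl, does to growth inhibition.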